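A few compounds are considered here, and "the series" means these few. Any claim that something is new, unique, unknown or untested is made for them only; others in the source may bear on it.

Working notes on the series. Compound 1 `O=C1O/C(=C\Cn2cnc3c(F)nc(F)c(Cl)c32)C(OCc2ccccc2)=C1OCc1ccccc1` in a functional assay on CCRF-CEM cells (Homo sapiens) for antiproliferative activity, read by MTT assay, with a stated time of 72 h (on this read-out lower numbers stand for stronger inhibition and higher numbers for weaker inhibition), gives "not determined" (no result reported): no single number is reported for it, and a further entry likewise gives no single number. Compound 2 `O=C1NC(O)(CCn2cnc3ccn(CCC4(O)NC(=O)C(OCc5ccccc5)=C4OCc4ccccc4)c3c2=O)C(OCc2ccccc2)=C1OCc1ccccc1` in this assay gives 15000 nM; 4900 nM (2 entries); the spread between its two entries, (the several entries of compound 2 in this assay, 15000 nM; 4900 nM (2 entries)), shows how far repeats of this kind can lie apart. Compound 3 `O=C1NC(O)(CCn2cnc3cc[nH]c3c2=O)C(OCc2ccccc2)=C1OCc1ccccc1` in this assay gives 87000 nM. Both measured compounds sit in the weak range of this assay, and neither shares the core of compound 1.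

Compound 4 `O=C1O/C(=C\Cn2cnc3ncc(Br)c-3c2)C(OCc2ccccc2)=C1OCc1ccccc1` is not yet measured. It differs from compound 1 by a group of 10 heavy atoms (6 carbon, 3 nitrogen, 1 bromine; one five-membered aromatic ring with 1 hetero atom, one six-membered aromatic ring with 2 hetero atoms) in place of a group of 12 heavy atoms (6 carbon, 3 nitrogen, 2 fluorine, 1 chlorine; one five-membered aromatic ring with 2 hetero atoms, one six-membered aromatic ring with 1 hetero atom), on a saturated chain carbon bound to a double-bonded chain carbon. Within the data shown here, no measured pair carries this change, so its size and direction cannot be read from the data, and compound 1 itself offers no number to step from. With only the weak values of compound 2 and compound 3 as anchors, any expectation for this core is loose.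

Compound 4 is expected to give in this assay about 20000 nM, within a range from 3000 nM to 100000 nM, with a fair chance that only a limit is reported.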

Compound 4, half-maximal inhibitory concentration: 12000 nM
The estimate for compound 4 lay 1.7-fold (0.22 log units) above the measured number, and the stated range covers the measured number.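

Among these compounds, compound 1 has no single number, so no step to compound 4, which gives 12000 nM in this assay, can be read. The compounds shown leave open how the group entering on compound 4 compares with the group it replaces. Nothing at hand accounts for the value of compound 4.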